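The source may report more compounds than this note shows. Statements on the series, on what has been measured and on what is new or still open speak of the compounds shown alone.

Three compounds have been measured in an assay on AV12 cells for binding affinity to Neuropeptide Y receptor type 1 (Homo sapiens); a lower number here means a stronger inhibitor, a higher number a weaker inhibitor:

Compound 1, `Cc1cccc2c1nc(COc1ccc(Cl)cc1)n2CCCC1CCN(C)CC1`, gives 52 nM.
Compound 2, `Cc1cccc2c1nc(COc1ccc(Cl)cc1)n2CCCC1CCN(CCC(C)C)CC1`, gives 11 nM.
Compound 3, `Cc1cccc2c1nc(COc1ccc(Cl)cc1)n2CCCC1CCN(CCCCN2CCCCC2)CC1`, gives 52 nM; 5.7 nM (2 entries).

Among the single numbers, compound 2 gives the lowest; its nearest neighbour is compound 1, and the only measured step, a 4.7-fold lower number from compound 1 to compound 2 (0.67 log units; beyond the scatter), came from isobutyl in place of hydrogen on a saturated chain carbon bound to an amine nitrogen in a ring. Compound 3 has no single number, and the spread in the several entries of compound 3 in this assay, 52 nM; 5.7 nM (2 entries) shows how far repeat measurements can fall apart.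

Compound 4, `Cc1cccc2c1nc(COc1ccc(Cl)cc1)n2CCCC1CCN(C(=O)CCN2CCCCC2)CC1`, differs from compound 2 by (2-(piperidin-1-yl)ethyl)carbonyl in place of isopentyl on an amine nitrogen in a ring. For the measured compounds named here, no measured step trades an alkyl chain on this nitrogen for a carbonyl-bearing group, so the measured step gives little guidance, and a moderate weakening is expected, a 3.2-fold higher number from compound 2 to compound 4 (0.50 log units; beyond the scatter). Compound 4 is therefore estimated at 35 nM, with a range from 7 nM to 180 nM.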

Compound 4, inhibition constant: 260 nM
Compound 4: middle estimate off by 7.4-fold (0.87 log units), on the low side; measured number outside the range, above it.
By their numbers in this assay, from the lowest: compound 2; then compound 1; then compound 4.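

On this ring nitrogen, (2-(piperidin-1-yl)ethyl)carbonyl does not keep the gain seen with isopentyl: replacing isopentyl gives a 24-fold higher number from compound 2 to compound 4 (1.37 log units; beyond the scatter), and replacing even the small methyl gives a 5.0-fold higher number from compound 1 to compound 4 (0.70 log units; beyond the scatter). A larger group on this nitrogen therefore does not by itself give a lower number. Compound 3 also carries a piperidine, without the carbonyl, but it gives no single number for comparison: the several entries of compound 3 in this assay, 52 nM; 5.7 nM (2 entries)

Whether the carbonyl or the piperidine accounts for the weakening stays open. A plain acetyl on this nitrogen would separate the two.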